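Shortening the side chain: from compound 3 to compound 4

A few compounds are considered here, and "the series" means these few. Any claim that something is new, unique, unknown or untested is made for them only; others in the source may bear on it.

Three compounds have been measured in a functional assay on MV cells (Homo sapiens) for inhibition, read by sulforhodamine B assay; on this read-out higher numbers stand for weaker inhibition and lower numbers for stronger inhibition:
compound 1 `C#CC(=O)N1C(c2ccc(C#N)cc2)SC[C@@H]1C(=O)OCC`, 2400 nM
compound 2 `C#CC(=O)N1C(c2ccc(OC)cc2)SC[C@@H]1C(=O)OCC`, 700 nM
compound 3 `C#CC(=O)N1C(CC(C)CC(C)(C)C)SC[C@@H]1C(=O)OCC`, 1100 nM

Compound 3 stands second highest of these three numbers; its nearest neighbour is compound 2, whose value lies within the scatter of it, while compound 1 lies beyond the scatter above it. Compound 4 `C#CC(=O)N1C(CCCCC)SC[C@@H]1C(=O)OCC` differs from compound 3 by butyl in place of 1,3,3-trimethylbutyl on a saturated chain carbon bound to a saturated ring carbon. Within the data shown here, the only measured step, a 3.4-fold lower number from compound 1 to compound 2 (0.54 log units; beyond the scatter), concerns a substituent on an aromatic carbon and does not touch the saturated chain, so no measured step bears on this change. Compound 4 is therefore expected to give a number close to that of compound 3, with no change at the digits printed from compound 3 to compound 4 (within the scatter) not beyond the scatter. The estimate for compound 4 in this assay is 1100 nM, between 400 nM and 3200 nM.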

Compound 4, half-maximal inhibitory concentration: 2000 nM
The estimate for compound 4 lay 1.8-fold (0.26 log units) below the measured number; the measured number falls inside the stated range.
By their numbers in this assay, from the lowest: compounds 2, 3, 4 and 1 (each within the scatter of the next, the first and the last beyond it).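

The first step read at this place, on a saturated chain carbon bound to a saturated ring carbon, is a 1.8-fold higher number from compound 3 to compound 4 (0.26 log units; within the scatter) in this assay. Butyl in place of 1,3,3-trimethylbutyl therefore does not separate the two compounds, although the branched chain and the unbranched one differ in heavy atom count. Nothing available accounts for this result. The compounds shown leave open how a longer chain, an amine or a carboxylic acid would read at this place. They also leave open whether a chain shorter than butyl would keep the number within the scatter of compound 3.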